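Pyridyl isomer step in the methoxy series

A few compounds are considered here, and "the series" means these few. Any claim that something is new, unique, unknown or untested is made for them only; others in the source may bear on it.

Values in an ADME assay on microsomes from liver (Rattus norvegicus) for metabolic stability; on this read-out higher numbers stand for a longer-lived compound and lower numbers for a shorter-lived compound:
- compound 1 `COc1cc(OCc2csc(-c3ccc(C(F)(F)F)cc3)n2)c2cc(-c3cn4nc(OC)sc4n3)oc2c1`: 1.42 h
- compound 2 `COc1cc(OCc2cccc(-c3ccc(OC)nc3)c2)c2cc(-c3cn4nc(OC)sc4n3)oc2c1`: 0.633 h

Compound 2, at 0.633 h, holds the lower of the two values. Compound 1, at 1.42 h, stands higher, and the gap lies beyond the usual scatter.

Compound 3 `COc1ccc(-c2cccc(COc3cc(OC)cc4oc(-c5cn6nc(OC)sc6n5)cc34)c2)nc1` has the same atoms as compound 2, joined differently 5-methoxypyridin-2-yl in place of 6-methoxypyridin-3-yl on an aromatic carbon of a six-membered aromatic ring of carbon only, meta to a large group.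

Going by the values given here, no measured pair shows this kind of change, so the direction in this assay remains open, and no step beyond the scatter is expected. The expected step of a 1.1-fold higher number from compound 2 to compound 3 (0.04 log units; within the scatter) is small. The starting point is compound 2 at 0.633 h. The estimate for compound 3 is 0.7 h, with an expected range of 0.35 h to 1.4 h.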

Compound 3, half-life: 0.317 h
Beside the measured number, compound 3's estimate is 2.2-fold (0.34 log units) above it, outside the stated range (below it).
By their numbers in this assay, from the lowest: compounds 3 and 2 (each within the scatter of the next); then compound 1.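

Going by these compounds alone, this is the only pair that differs in one place. In this assay, 5-methoxypyridin-2-yl in place of 6-methoxypyridin-3-yl gives a 2.0-fold lower number from compound 2 to compound 3 (0.30 log units; within the scatter), so this isomer exchange, on an aromatic carbon meta to a large group, separates the two compounds by no more than repeated measurements would. With the same atoms joined differently, this one pair gives no direction for the change at this position, and nothing at hand bears on what lies behind the result.

Still open, on these data alone, is how this position responds to groups other than the two methoxypyridine isomers, such as an unsubstituted phenyl, a carboxylic acid or a dimethylamino group. Also open, as far as these compounds go, is whether the same isomer exchange would behave alike with the core of compound 3 altered elsewhere.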